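Replacing the ester side group of compound 2

The compounds below may be only part of what the source reports. "The series", "measured", "known", "first", "only" and "open" are said of these compounds alone.

compound 1 `C=C1C(=O)O[C@H]2CC3=C[C@H](C/C(C)=C/[C@@H](OC(=O)c4ccc(C(C)=O)cc4)[C@H]12)OC3=O` gives 2200 nM
compound 2 `C=C1C(=O)O[C@H]2CC3=C[C@H](C/C(C)=C/[C@@H](OC(=O)C(C)(C)CC)[C@H]12)OC3=O` gives 6100 nM

In a functional assay on NCI-H460 cells (Homo sapiens) for cytotoxicity, read by MTT assay, with a stated time of 48 h (on this read-out higher numbers stand for weaker inhibition and lower numbers for stronger inhibition), compound 2 (6100 nM) stands highest of the two measured compounds. Compound 3 (`C=C1C(=O)O[C@H]2CC3=C[C@H](C/C(C)=C/[C@@H](OC(=O)/C=C/c4ccncc4)[C@H]12)OC3=O`) carries 2-(pyridin-4-yl)ethenyl in place of 1,1-dimethylpropyl on a carbonyl carbon. Within the data shown here, one measured step bears on this (a 2.8-fold higher number from compound 1 to compound 2 (0.44 log units; beyond the scatter)), a modest one that brought in 1,1-dimethylpropyl where 4-acetylphenyl had stood. The new change runs the other way, back to a group with an aromatic ring, so a similarly modest move to a lower number in this assay is expected, though a single step is thin evidence. The expected change is a 2.2-fold lower number from compound 2 to compound 3 (0.34 log units; beyond the scatter) (an estimate). The estimated value for compound 3 is 2800 nM (expected range 1000 nM to 7500 nM).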

Compound 3, half-maximal inhibitory concentration: 2100 nM
Compound 3: middle estimate off by 1.3-fold (0.12 log units), on the high side; the range from low to high includes it.
By their numbers in this assay, from the lowest: compounds 3 and 1 (each within the scatter of the next); then compound 2.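

In this assay the 2-(pyridin-4-yl)ethenyl group gives a 2.9-fold lower number from compound 2 to compound 3 (0.46 log units; beyond the scatter) and so joins 4-acetylphenyl on the lower side of 1,1-dimethylpropyl. Set against 4-acetylphenyl, it gives a 1.0-fold lower number from compound 1 to compound 3 (0.02 log units; within the scatter) and the two ring-bearing groups cannot be told apart, although only one has a ring nitrogen and only one has a double bond outside the ring. Nothing at hand explains why these groups differ from 1,1-dimethylpropyl. Still open, from the compounds shown here alone, is how an unsubstituted phenyl or a straight hexyl chain would compare at this position.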